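A Methyl on the Pyrrolidine Ring: Compound 2 to Compound 4

The source may hold more compounds than are shown below. What is called first, only, known or untested is meant among the compounds shown, and "the series" means these compounds.

compound 1 `CN(C)c1c(C#N)c2c(N)ncnc2n1C` — 3760 nM
compound 2 `Cn1c(N2CCCC2)c(C#N)c2c(N)ncnc21` — 1910 nM
compound 3 `Cc1c(Nc2nc(N)c3c(C#N)c(N4CCC[C@H]4C)n(C)c3n2)cnn1C1COC1` — 37 nM

Of the compounds shown here, three share one core and have been measured in an assay on isolated protein for inhibition of Leucine-rich repeat serine/threonine-protein kinase 2 variant G2019S (Homo sapiens), read by TR-FRET and LanthaScreen, with stated times of 50 min and 30 min, in the presence of a further agent that is not named here; on this read-out lower numbers stand for stronger inhibition and higher numbers for weaker inhibition. Compound 2 gives 1910 nM, the second highest of the three numbers. Compound 1 gives 3760 nM, a number within the scatter of that of compound 2. Compound 3 gives 37 nM, far lower and beyond the scatter, but compound 3 differs from compound 2 in more than one place, so its number alone cannot be tied to any single change.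

Compound 4 `C[C@H]1CCCN1c1c(C#N)c2c(N)ncnc2n1C` has not yet been measured. Its difference from compound 2 is methyl in place of hydrogen on a saturated ring carbon; cut one bond further out, the change reads pyrrolidin-1-yl to 2-methylpyrrolidin-1-yl.

Going by the values given here, only one measured step is available, a 2.0-fold lower number from compound 1 to compound 2 (0.29 log units; within the scatter), and it exchanges the whole amine rather than adding a methyl to the ring, so it does not speak to this change. As far as these compounds go, compound 3 does carry 2-methylpyrrolidin-1-yl, but the size of its other change is unknown. The expectation therefore rests on little: a step of modest size, if any, with direction open.

Compound 4 is estimated at 1000 nM in this assay, with a range from 300 nM to 3000 nM, which means an expected step of a 1.9-fold lower number from compound 2 to compound 4 (0.28 log units; within the scatter).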

Compound 4, half-maximal inhibitory concentration: 3080 nM
The estimate for compound 4 lay 3.1-fold (0.49 log units) below the measured number; measured number above the stated range.
By their numbers in this assay, from the lowest: compound 3; then compounds 2, 4 and 1 (each within the scatter of the next).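

In this assay, going by these compounds alone, adding a methyl to the saturated ring carbon next to the ring nitrogen gives a 1.6-fold higher number from compound 2 to compound 4 (0.21 log units; within the scatter), so this change on the shared core leaves no step that can be told apart from the scatter. Replacing the whole amine points the same way, with a 1.2-fold lower number from compound 1 to compound 4 (0.09 log units; within the scatter), and the three compounds that carry only dimethylamino, pyrrolidin-1-yl or 2-methylpyrrolidin-1-yl on the core therefore stand within the scatter of one another. The printed values also show that 2-methylpyrrolidin-1-yl alone does not bring the low number seen for compound 3, since compound 4 carries that group and gives 3080 nM, whereas compound 3 gives 37 nM.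

As far as these compounds go, whether an ethyl or a hydroxymethyl on the same ring carbon, or a six-membered piperidin-1-yl in place of the pyrrolidine, would produce a step beyond the scatter remains open, as does the size of the methyl step on the core of compound 3. Nothing available here explains the results for these amines.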